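A Carbamoyl Group Enters a Tail Flick Series

This account rests on a few compounds, and the source may have more. Where it says the series, first, only, none or still open, it means among the compounds named here.

Measured compounds:
compound 1, `C[C@H](NC(=O)CN(c1nc(Cl)nc2[nH]cnc12)C1CC1)C(=O)OCc1ccccc1`, 44.2%
compound 2, `C[C@H](NC(=O)CN(c1nc(Cl)nc2[nH]cnc12)C1CC1)C(=O)O`, 43.5%

In a functional assay on the whole organism (Tail, strain ICR) with Mus musculus as the target, in the tail flick test, with a stated time of 90 min, at a dose of 25 umol/kg by the oral route (a lower number here means a weaker effect, a higher number a stronger effect of the compound at the dose given), compound 1 gives 44.2%, the higher of the two numbers, and compound 2 gives 43.5%. Among the measured compounds shown here, the only measured step, a number 0.7 percentage points lower from compound 1 to compound 2 (within the scatter), lies within the scatter, so the two values cannot be told apart.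

Compound 3, `NC(=O)C[C@H](NC(=O)CN(c1nc(Cl)nc2[nH]cnc12)C1CC1)C(=O)OCc1ccccc1`, differs from compound 1 by carbamoyl in place of hydrogen on a saturated chain carbon, two bonds along the chain from an amide-type nitrogen and a carbonyl carbon. For the measured compounds named here, no measured step touches this part of the molecule; the one step known, a number 0.7 percentage points lower from compound 1 to compound 2 (within the scatter), concerns a different position and was within the scatter, so it offers no direction for the present change. With nothing to point either way, compound 1 is taken as the anchor and no step beyond the scatter is expected, though a sizeable uncertainty remains.

Compound 3 is therefore estimated at 42%, within a range of 22% to 62%. This expectation amounts to a number 2.2 percentage points lower from compound 1 to compound 3 (within the scatter).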

Compound 3, a percentage reported as activity, at one dose (the size of the read-out at that dose, not a potency): 32.3%
Compound 3: the middle estimate sits 9.7 percentage points above what was measured, within the range that was stated.
By their numbers in this assay, from the lowest: compound 3; then compounds 2 and 1 (each within the scatter of the next).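

In this assay, among the compounds shown here, carbamoyl in place of hydrogen gives a number 11.9 percentage points lower from compound 1 to compound 3 (beyond the scatter), the first step to lie beyond the scatter. The saturated chain carbon, two bonds along the chain from an amide-type nitrogen and a carbonyl carbon, is therefore a place where a change alters the read-out at this dose, whereas the earlier change at another position gave a number 0.7 percentage points lower from compound 1 to compound 2 (within the scatter). Nothing measured on these compounds accounts for the step.

The compounds shown leave open whether a carboxylic acid, an amine or a longer chain at this carbon would lower the number in the same way as carbamoyl. They also leave open whether hydrogen in place of benzyl would still leave the number within the scatter once carbamoyl is present.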